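From 4-fluorobenzyl to allyl on the sulfur chain

The compounds below may be only part of what the source reports. "The series", "measured", "known", "first", "only" and "open" are said of these compounds alone.

In a functional assay on BGC-823 cells (Homo sapiens) for inhibition, read by MTT assay, with a stated time of 72 h (a lower number here means a stronger inhibitor, a higher number a weaker inhibitor), compound 1 (`Cc1cc(N2CC[C@@H](C)[C@@H](N(C)c3ncnc4[nH]ccc34)C2)n2ncnc2n1`) gives 67400 nM and compound 2 (`Cc1cc(N2CC[C@@H](C)[C@@H](N(C)c3ncnc4[nH]ccc34)C2)n2nc(SCc3ccc(F)cc3)nc2n1`) gives 44300 nM as its reading. Only these two numbers exist so far, and they lie within the scatter of each other, so compound 2 stands level with compound 1.

Compound 3 (`C=CCSc1nc2nc(C)cc(N3CC[C@@H](C)[C@@H](N(C)c4ncnc5[nH]ccc45)C3)n2n1`) alters the end of the sulfur chain of compound 2: vinyl in place of 4-fluorophenyl on a saturated chain carbon bound to a sulfur is the change, vinyl in place of 4-fluorophenyl on a saturated chain carbon bound to a sulfur.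

Within the data shown here, one measured step bears on this. Adding the whole (4-fluorobenzyl)sulfanyl group gave a 1.5-fold lower number from compound 1 to compound 2 (0.18 log units; within the scatter) and stayed within the scatter, so exchanging only part of that group should matter little. In this assay the expected move is a 1.1-fold higher number from compound 2 to compound 3 (0.05 log units; within the scatter) and no shift beyond the scatter is expected in either direction. Compound 3 is estimated at 50000 nM (expected range 25000 nM to 100000 nM).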

Compound 3, half-maximal inhibitory concentration: 40900 nM
For compound 3 the middle estimate is 1.2-fold (0.09 log units) above the measured one; measured number inside the range.
By their numbers in this assay, from the lowest: compounds 3, 2 and 1 (each within the scatter of the next).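

In this assay, vinyl in place of 4-fluorophenyl on the saturated chain carbon bound to a sulfur gives a 1.1-fold lower number from compound 2 to compound 3 (0.03 log units; within the scatter), so at this place a group with an aromatic ring and a group with no ring read alike. Allylsulfanyl in place of hydrogen on the aromatic carbon gives a 1.6-fold lower number from compound 1 to compound 3 (0.22 log units; within the scatter), so a second group on the sulfur also stays level with the compound that has no sulfur chain at all. Nothing measured here explains why these compounds read alike.

Still open, as far as these compounds go, is whether a different end to the sulfur chain, such as an amine, a carboxylic acid or a longer alkyl chain, would move the number beyond the scatter. With all three compounds level, these results cannot yet tell the sulfur-linked groups apart.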